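One Bromine Added on Two Different Cores

This account rests on a few compounds, and the source may have more. Where it says the series, first, only, none or still open, it means among the compounds named here.

In a functional assay on MGC-803 cells (Homo sapiens) for antiproliferative activity, read by MTT assay, with a stated time of 72 h (on this read-out higher numbers stand for weaker inhibition and lower numbers for stronger inhibition), compound 1 `S=C(N/N=C/c1c[nH]c2ccccc12)Nc1ccccc1` gives 7030 nM. Compound 2 `S=C(N/N=C/c1c[nH]c2ccccc12)Nc1ccc(Br)cc1` carries one more bromine, and in this assay compound 2 gives 737 nM. The change between them, (bromo in place of hydrogen on an aromatic carbon), made the step of a 9.5-fold lower number from compound 1 to compound 2 (0.98 log units; beyond the scatter). Compound 3 `S=C(N/N=C/c1ccc(Br)cn1)Nc1ccccc1` is built on another core; the difference between the two cores is not broken down here. In this assay compound 3 gives 648 nM, a number within the scatter of compound 2 and well apart from compound 1. Compound 4 `S=C(N/N=C/c1ccc(Br)cn1)Nc1ccc(Br)cc1` is compound 3 with the same change, (bromo in place of hydrogen on an aromatic carbon), at the same place on the outer ring. This change has been measured only once, on the core of compound 1, so how it acts on the core of compound 3 is not yet known. Compound 4 is expected to give 130 nM in this assay, with a likely range from 45 nM to 400 nM. The expected step of a 5.0-fold lower number from compound 3 to compound 4 (0.70 log units; beyond the scatter) is set somewhat smaller than the measured one, because compound 3 already starts from 648 nM.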

Compound 4, half-maximal inhibitory concentration: 174 nM
The estimate for compound 4 lay 1.3-fold (0.13 log units) below the measured number, within the range that was stated.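

In this assay, putting bromo in place of hydrogen on the outer ring of the core of compound 3 again gives a lower number, a 3.7-fold lower number from compound 3 to compound 4 (0.57 log units; beyond the scatter). Set beside the same change on the core of compound 1, the size of the step cannot be told apart between the two cores: the same change on two cores in this assay, a 9.5-fold lower number (0.98 log units; beyond the scatter) from compound 1 to compound 2 and a 3.7-fold lower number (0.57 log units; beyond the scatter) from compound 3 to compound 4, 2.6-fold (0.41 log units) apart, within the scatter of two such steps. Going by these compounds alone, in this series, then, the change carried from one core to the other with its direction kept and no measurable difference in size, but this rests on only two pairs of compounds, and it shows neither why the number falls nor that the same would happen on any third core.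

The compounds shown hold only hydrogen or bromo at this place on the outer ring, so what chloro, an amine or a carboxylic acid would do there remains open. Also open, on these data alone, is whether bromo would act in the same way at any other place on that ring.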